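The compounds below may be only part of what the source reports. "The series", "measured", "known", "first", "only" and "open" are said of these compounds alone.

Measured in a functional assay on HL-60 cells (Homo sapiens) for inhibition, read by MTT assay, with a stated time of 72 h; a higher number here means a weaker inhibitor, a lower number a stronger inhibitor:
Compound 1 `CO[C@@H]1[C@H]2OC(=O)C[C@H]2O[C@@H]1C(=O)c1ccccc1`: 11200 nM
Compound 2 `CO[C@@H](c1ccccc1)[C@H]1O[C@@H]2CC(=O)O[C@@H]2[C@H]1O`: 1630 nM

Of these two, compound 2 has the lower number, 1630 nM, and its gap to compound 1 lies beyond the scatter. Compound 3 `CO[C@H](c1ccccc1)[C@H]1O[C@@H]2CC(=O)O[C@@H]2[C@H]1O` has not yet been measured. It departs from compound 2 by the two compounds have the same atoms and bonds and differ only in configuration as drawn: 1 of 5 stereo elements differ; a stereocentre at a saturated chain carbon is drawn S in compound 2 and R in compound 3: a stereocentre at a saturated chain carbon is drawn S in compound 2 and R in compound 3. For the measured compounds named here, no measured pair shows what such a change does, so only a modest shift is expected, not beyond the scatter. The expected change in this assay is a 1.4-fold higher number from compound 2 to compound 3 (0.15 log units; within the scatter). For compound 3 the estimated value is 2300 nM, with an expected range of 600 nM to 9000 nM.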

Compound 3, half-maximal inhibitory concentration: 2960 nM
The estimate for compound 3 lay 1.3-fold (0.11 log units) below the measured number, and the stated range covers the measured number.
By their numbers in this assay, from the lowest: compounds 2 and 3 (each within the scatter of the next); then compound 1.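

In this assay, for the compounds shown here, drawing a stereocentre at a saturated chain carbon as R rather than S gives a 1.8-fold higher number from compound 2 to compound 3 (0.26 log units; within the scatter), the first direct reading of a change at this position. The step applies to that stereocentre alone, because nothing else separates the pair: the fact that compounds 2 and 3 differ only in the configuration as drawn. On these numbers, the configuration at this carbon makes no difference beyond the scatter in this assay.

Still open, as far as these compounds go, is how this assay would respond if an amine or a longer chain stood at this stereocentre. From the compounds shown here alone, whether either configuration would then read alike also remains unknown.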